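Ring swap on a sulfur in a benzamide series

The compounds below may be only part of what the source reports. "The series", "measured", "known", "first", "only" and "open" are said of these compounds alone.

Of the compounds shown here, three have been measured in a functional assay on HCT-116 cells (Homo sapiens) for inhibition, read by CCK-8 assay, with a stated time of 72 h, tested at 8 uM; a higher number here means more inhibition of growth at the concentration tested, a lower number less inhibition of growth. Compound 1 `Cc1cc(C)cc(SCc2ccc(/C=C/C(=O)Nc3ccccc3N)cc2)c1` gives 4.2% in this assay, and compound 2 `Nc1ccccc1NC(=O)/C=C/c1ccc(CSc2ccc(Cl)cc2)cc1` gives 3.27%. Compound 3 `Nc1ccccc1NC(=O)c1ccc(CSc2ccc(Cl)cc2)cc1` gives 76.6% in this assay, the highest of the three, and its distance to both others lies beyond the scatter. The difference between the cores of compound 3 and compound 2 is not broken down here.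

Between compound 2 and compound 1 one change is made: 3,5-dimethylphenyl in place of 4-chlorophenyl on a sulfur The step was a number 0.9 percentage points higher from compound 2 to compound 1 (within the scatter).

Compound 4 `Cc1cc(C)cc(SCc2ccc(C(=O)Nc3ccccc3N)cc2)c1` is not yet measured. It differs from compound 3 by the same change, at the same place: 3,5-dimethylphenyl in place of 4-chlorophenyl on a sulfur Since the earlier step from compound 2 to compound 1 was a number 0.9 percentage points higher from compound 2 to compound 1 (within the scatter), the change is expected to leave this assay value largely where compound 3 stands, with the caution that both earlier compounds sat at very low inhibition, so the step there tells little about a compound starting high. For compound 4 the expected step is a number 11.6 percentage points lower from compound 3 to compound 4 (beyond the scatter). Compound 4 is therefore estimated at 65%, with a range from 40% to 85%.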

Compound 4, percent growth inhibition at one concentration: 72.9%
For compound 4 the middle estimate is 7.9 percentage points below the measured one; the measured number falls inside the stated range.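

The new step in this assay is a number 3.7 percentage points lower from compound 3 to compound 4 (within the scatter), for 3,5-dimethylphenyl in place of 4-chlorophenyl on a sulfur. Set beside the earlier step, the change reads the same on both cores: the same change on two cores in this assay, a number 0.9 percentage points higher (within the scatter) from compound 2 to compound 1 and a number 3.7 percentage points lower (within the scatter) from compound 3 to compound 4, 4.6 percentage points apart, within the scatter of two such steps. Among these compounds, this does not show that the swap is harmless in general, since only two cores and one pair of rings stand behind it, and the two compounds on the core of compound 1 both sit at very low inhibition, so only the pair on the core of compound 3 tests the change from a high starting value.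

The compounds shown leave open how a cyclohexyl ring or a 4-methoxyphenyl on the sulfur would read in this assay and whether an oxygen in place of the sulfur would keep the value. They also leave open whether compound 3 and compound 4 would stay together at concentrations other than the single one tested.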